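Hexylsulfonyl in Place of Ethylsulfanyl on a Shared Coumarin-Free Core

A few compounds are considered here, and "the series" means these few. Any claim that something is new, unique, unknown or untested is made for them only; others in the source may bear on it.

Compound 1 `CCSc1nnc(COc2cc(C)c3c(C)cc(=O)oc3c2)o1` gives > 100000 nM in a functional assay on MDA-MB-231 cells (Homo sapiens) for antiproliferative activity, read by MTT assay, with a stated time of 24 h (on this read-out higher numbers stand for weaker inhibition and lower numbers for stronger inhibition), which is a limit of the assay and not a number.
Compound 2 `Cc1cc(OCc2nnc(SCc3ccc(F)c(F)c3)o2)cc2oc(=O)cc(C)c12` gives > 100000 nM in this assay, again a limit.
Compound 3 `CCS(=O)(=O)c1nnc(COc2cc(C)c3c(C)cc(=O)oc3c2)o1` gives > 100000 nM in this assay, also a limit.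

All three measured values sit at the limit of > 100000 nM in this assay, at which 3 of the 3 values shown sit, so compound 1 stands at the limit, on the same footing as the other two. The measured steps that vary the group on the five-membered ring, a step that the two limits leave unreadable from compound 1 to compound 2, a step that the two limits leave unreadable from compound 1 to compound 3 and a step that the two limits leave unreadable from compound 2 to compound 3, cannot be sized, since each joins two limits.

Compound 4 `CCCCCCS(=O)(=O)c1nnc(COc2cc(C)c3c(C)cc(=O)oc3c2)o1` differs from compound 1 by hexylsulfonyl in place of ethylsulfanyl on an aromatic carbon. The step from compound 1 to compound 3 is the closest comparison, as it also introduces a sulfonyl on that ring carbon, and it too ended at the limit. For the measured compounds named here, no measured step points in either direction, so the expectation is that compound 4 stays at the limit, and the step that the limit leaves unreadable from compound 1 to compound 4 is estimated to be none that the assay can read. Compound 4 is expected to give about 150000 nM, with a range from 50000 nM to 500000 nM.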

Compound 4, half-maximal inhibitory concentration: > 100000 nM
Compound 4: no number, only a limit; the forecaster's own chance of this, stated with the estimate: 85%; the middle value does not contradict the limit.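

Compound 4 gives > 100000 nM in this assay, which is a limit of the assay and not a number. Its steps with compound 1, compound 2 and compound 3 cannot be read, since each joins two limits: the limit of > 100000 nM in this assay, at which 4 of the 4 values shown sit.

The compounds shown leave open how strongly any of the four acts on these cells, and whether the group on the five-membered ring matters at all.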